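Methyl to Methoxy on the Para Aryl Substituent

The source may report more compounds than this note shows. Statements on the series, on what has been measured and on what is new or still open speak of the compounds shown alone.

Compound 2 `Cc1ccc(C2=NN(C3=NC(=O)CS3)C(c3cccc4ccccc34)C2)cc1` gives 3210 nM in a functional assay on HeLa cells (Homo sapiens) for inhibition, read by CCK-8 assay, with a stated time of 48 h (a lower number here means a stronger inhibitor, a higher number a weaker inhibitor), the lowest of the two numbers recorded so far. Its nearest neighbour is compound 1 `O=C1CSC(N2N=C(c3ccc(F)cc3)CC2c2cccc3ccccc23)=N1`, which in this assay gives 11300 nM; the step of a 3.5-fold lower number from compound 1 to compound 2 (0.55 log units; beyond the scatter) came from methyl in place of fluoro on an aromatic carbon. Compound 3 `COc1ccc(C2=NN(C3=NC(=O)CS3)C(c3cccc4ccccc34)C2)cc1` has not yet been measured. It differs from compound 2 by methoxy in place of methyl on an aromatic carbon. Within the data shown here, only one measured step touches this position, and it concerns a different swap at the same aromatic carbon: a 3.5-fold lower number from compound 1 to compound 2 (0.55 log units; beyond the scatter) showed that a change there can move the number modestly. Nothing measured here shows what a methoxy does at that place, so the expectation rests on that single prior step and on the usual scatter. Compound 3 is therefore expected to sit close to compound 2. The expected step of a 1.1-fold lower number from compound 2 to compound 3 (0.03 log units; within the scatter) may well stay within the scatter in either direction. The estimate for compound 3 in this assay is 3000 nM, with a range from 1000 nM to 9000 nM.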

Compound 3, half-maximal inhibitory concentration: 2540 nM
Beside the measured number, compound 3's estimate is 1.2-fold (0.07 log units) above it; measured number inside the range.
By their numbers in this assay, from the lowest: compounds 3 and 2 (each within the scatter of the next); then compound 1.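

In this assay, swapping methyl for methoxy on this aromatic carbon gives a 1.3-fold lower number from compound 2 to compound 3 (0.10 log units; within the scatter), so adding an oxygen and a hydrogen-bond acceptor at this place does not separate the two compounds beyond the usual scatter. The second comparison, a 4.4-fold lower number from compound 1 to compound 3 (0.65 log units; beyond the scatter), lies beyond the scatter, as does a 3.5-fold lower number from compound 1 to compound 2 (0.55 log units; beyond the scatter), so among these three compounds it is the fluoro group of compound 1 that stands apart, while the methyl and methoxy groups cannot be told from each other. No independent evidence is available to explain this grouping.

The compounds shown leave open what a hydroxyl, an amine or a longer chain such as ethoxy would do on this aromatic carbon, and whether a chloro group would fall with fluoro or with methyl and methoxy. They also leave open whether methoxy would give a similar result at another carbon of this ring, as all three substituents stand para to a large group.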